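A Combined Chloro and Trifluoromethyl Amide: Expected Toxicity

This account rests on a few compounds, and the source may have more. Where it says the series, first, only, none or still open, it means among the compounds named here.

Three related amides share one core. Compound 1 `Cc1ccc(C(=O)Nc2ccc(Cl)cc2)cc1C#Cc1cc(-c2cnn(C)c2)cnc1N` carries a 4-chlorophenyl group on the amide nitrogen, compound 2 `Cc1ccc(C(=O)Nc2cccc(C(F)(F)F)c2)cc1C#Cc1cc(-c2cnn(C)c2)cnc1N` a 3-(trifluoromethyl)phenyl group, and compound 3 `Cc1ccc(C(=O)Nc2ccc(C(F)(F)F)cc2)cc1C#Cc1cc(-c2cnn(C)c2)cnc1N` a 4-(trifluoromethyl)phenyl group. In an ADME assay on RBL-2H3 cells (Rattus norvegicus) for cytotoxicity, read by CCK-8 assay, with a stated time of 24 h (on this read-out lower numbers stand for higher toxicity in this test and higher numbers for lower toxicity in this test), compound 1 gives 269 nM, compound 2 gives 7 nM, and compound 3 gives 14 nM. Compound 3 thus has the second highest of the three numbers: it stands close to compound 2 and well away from compound 1, the step being a 19-fold lower number from compound 1 to compound 3 (1.28 log units; beyond the scatter). Compound 4 `Cc1ccc(C(=O)Nc2ccc(Cl)c(C(F)(F)F)c2)cc1C#Cc1cc(-c2cnn(C)c2)cnc1N` differs from compound 3 by 4-chloro-3-(trifluoromethyl)phenyl in place of 4-(trifluoromethyl)phenyl on an amide-type nitrogen. The measured steps that bear on this change are a 19-fold lower number from compound 1 to compound 3 (1.28 log units; beyond the scatter) and a 38-fold lower number from compound 1 to compound 2 (1.58 log units; beyond the scatter), both large, while a 2.0-fold higher number from compound 2 to compound 3 (0.30 log units; within the scatter). Both measured trifluoromethyl compounds give low numbers, and compound 4 keeps a trifluoromethyl group while adding a chloro. The expectation for compound 4 in this assay is therefore only a small step, a 1.4-fold lower number from compound 3 to compound 4 (0.15 log units; within the scatter), if any beyond the scatter. Compound 4 is estimated at 10 nM, within a range from 3 nM to 35 nM.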

Compound 4, half-maximal cytotoxic concentration: 21 nM
The estimate for compound 4 lay 2.1-fold (0.32 log units) below the measured number, and the stated range covers the measured number.
By their numbers in this assay, from the lowest: compounds 2, 3 and 4 (each within the scatter of the next, the first and the last beyond it); then compound 1.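

Compound 4 shows that the two groups can be separated on the same phenyl ring on the amide nitrogen. Adding trifluoromethyl to the 4-chlorophenyl group of compound 1 gives the large step, a 13-fold lower number from compound 1 to compound 4 (1.11 log units; beyond the scatter) in this assay, while adding chloro to the 3-(trifluoromethyl)phenyl group of compound 2 gives only a modest one, a 3.0-fold higher number from compound 2 to compound 4 (0.48 log units; beyond the scatter). Against the 4-(trifluoromethyl)phenyl group, the combined group stays within the scatter, at a 1.5-fold higher number from compound 3 to compound 4 (0.18 log units; within the scatter), so the two cannot be told apart here.

No measurement shown here explains any of these steps. As far as these compounds go, it remains open whether an amine or a carboxylic acid on this ring, in place of trifluoromethyl, would keep the number low or bring it back toward that of compound 1.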